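Trifluoromethyl added beside a ring fluorine in the retinal-type series

The source may hold more compounds than are shown below. What is called first, only, known or untested is meant among the compounds shown, and "the series" means these compounds.

The shared core of compound 1 `CC1=CCCC(C)(C)C1/C=C/C(=O)/C=C/c1ccccc1C(F)(F)F` carries a phenyl end group that varies across the set. In a functional assay on PCa 2b cells (Homo sapiens) for cytotoxicity, read by MTT assay, with a stated time of 72 h (on this read-out lower numbers stand for stronger inhibition and higher numbers for weaker inhibition), compound 1 gives "not determined" (no result reported), so no number is available for it. Compound 2 `CC1=CCCC(C)(C)C1/C=C/C(=O)/C=C/c1cccc(C(F)(F)F)c1` gives 4400 nM in this assay. Compound 3 `CC1=CCCC(C)(C)C1/C=C/C(=O)/C=C/c1ccccc1F` gives 8300 nM, the highest of the two numbers in this assay, but the gap to compound 2 lies within the scatter, so no order between them is claimed. Compound 4 `CC1=CCCC(C)(C)C1/C=C/C(=O)/C=C/c1cc(C(F)(F)F)ccc1F` differs from compound 3 by trifluoromethyl in place of hydrogen on an aromatic carbon. Among the measured compounds shown here, no step between measured compounds covers this change. Given that compound 2 gives 4400 nM with a trifluoromethyl on the ring, a small step downward is expected, a 1.7-fold lower number from compound 3 to compound 4 (0.22 log units; within the scatter), though within the scatter. Compound 4 is estimated at 5000 nM, with a range from 2000 nM to 15000 nM.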

Compound 4, half-maximal inhibitory concentration: 3000 nM
For compound 4 the middle estimate is 1.7-fold (0.22 log units) above the measured one, and the stated range covers the measured number.
By their numbers in this assay, from the lowest: compounds 4, 2 and 3 (each within the scatter of the next, the first and the last beyond it).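

In this assay, among the compounds shown here, trifluoromethyl para to a fluoro group gives the first step that clears the scatter (a 2.8-fold lower number from compound 3 to compound 4 (0.44 log units; beyond the scatter)). The matching step that introduces the fluoro group into the trifluoromethyl-bearing compound does not clear it (a 1.5-fold lower number from compound 2 to compound 4 (0.17 log units; within the scatter)), so that fluoro group has no resolved effect here. Nothing available explains these steps.

As far as these compounds go, whether a nitrile or a methoxy group at this position would give a similar step remains open. So does whether the step carries over to a core with a longer chain.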